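Swapping Methoxy for Chloro on the Cinnamate Ring

This account rests on a few compounds, and the source may have more. Where it says the series, first, only, none or still open, it means among the compounds named here.

Compound 1 `COc1cc(OC)c(OC)cc1/C=C/COC(=O)/C=C/c1ccc(Br)cc1`: 105 mg/kg
Compound 2 `COc1cc(OC)c(OC)cc1/C=C/COC(=O)/C=C/c1ccc(F)cc1`: 43.4 mg/kg
Compound 3 `COc1ccc(/C=C/C(=O)OC/C=C/c2cc(OC)c(OC)cc2OC)cc1`: 122 mg/kg
Compound 4 `COc1cc(OC)c(OC)cc1/C=C/COC(=O)/C=C/c1ccc(Cl)cc1`: not yet measured

In a functional assay on the whole organism (strain Kunming) with Mus musculus as the target, in the formalin test, with a stated time of 0.5 h (on this read-out higher numbers stand for an effect only at larger amounts of compound and lower numbers for an effect already at smaller amounts), compound 3 gives 122 mg/kg. It stands level with the bromo compound, as the data show a 1.2-fold higher number from compound 1 to compound 3 (0.07 log units; within the scatter). Only the fluoro compound stands clearly apart, with a 2.8-fold higher number from compound 2 to compound 3 (0.45 log units; beyond the scatter).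

Compound 4 keeps the core of compound 3 but carries chloro in place of methoxy on an aromatic carbon, para to a large group: chloro in place of methoxy on an aromatic carbon. In other words, 4-methoxyphenyl becomes 4-chlorophenyl.

For the measured compounds named here, no chloro compound has been measured so far, but chloro is a halogen, like the bromo of compound 1 and the fluoro of compound 2. Those two differ by a 2.4-fold lower number from compound 1 to compound 2 (0.38 log units; beyond the scatter), and the most direct guide is to expect chloro to fall somewhere within that span. Such a position would mean a move towards a lower number, no larger than the step seen for the fluoro compound. The expected step is a 1.7-fold lower number from compound 3 to compound 4 (0.24 log units; within the scatter).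

For compound 4 the estimate is 70 mg/kg, with an expected range from 38 mg/kg to 130 mg/kg.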

Compound 4, dose for half-maximal effect: 108 mg/kg
Estimate against measurement, compound 4: 1.5-fold (0.19 log units) below; the range from low to high includes it.
By their numbers in this assay, from the lowest: compound 2; then compounds 1, 4 and 3 (each within the scatter of the next).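

Chloro gives a result level with methoxy in this assay (a 1.1-fold lower number from compound 3 to compound 4 (0.05 log units; within the scatter)), and it is just as level with bromo (a 1.0-fold higher number from compound 1 to compound 4 (0.01 log units; within the scatter)). Against fluoro the picture differs (a 2.5-fold higher number from compound 2 to compound 4 (0.40 log units; beyond the scatter)), so of the four groups tried at this position on the cinnamate ring, fluoro alone stands apart, with the lowest number of the set. Being a halogen therefore does not by itself set the number here: chloro and bromo cannot be told from the non-halogen methoxy, and compound 2 is the one halogen compound that goes against any grouping of the halogens together.

As far as these compounds go, it remains open whether fluoro is a lone exception or one end of a wider trend, which other groups at this same position could test, such as a hydroxyl, an amine, a nitrile, a trifluoromethyl or a carboxylic acid. As for why fluoro alone separates from the other three, nothing among the available data speaks to it.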